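Benzyl for Phenyl on the Amide Nitrogen: Compound 4

The source may hold more compounds than are shown below. What is called first, only, known or untested is meant among the compounds shown, and "the series" means these compounds.

The measured compounds, all read in a functional assay on SW480 cells (Homo sapiens) for cytotoxicity, read by MTT assay, with a stated time of 24 h; on this read-out lower numbers stand for stronger inhibition and higher numbers for weaker inhibition:
Compound 1, `C=CC1=C(C(=O)NCc2ccc(Cl)cc2)C(c2ccc(OC)cc2)OC1`, reaches only the assay limit, > 100000 nM.
Compound 2, `C=CC1=C(C(=O)NC(C)(C)C)C(c2ccc(OC)cc2)OC1`, likewise reaches only the limit, > 100000 nM.
Compound 3, `C=CC1=C(C(=O)Nc2ccc(C)cc2)C(c2ccc(F)cc2)OC1`, reaches only the limit, > 100000 nM.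

Compound 3 therefore stands at a limit, not a number; the same limit, (the limit of > 100000 nM in this assay, at which 3 of the 3 values shown sit), holds for every measured compound. Among the measured compounds shown here, the one measured step, a step that the two limits leave unreadable from compound 1 to compound 2, runs between two limits and its size cannot be read. Compound 4, `C=CC1=C(C(=O)NCc2ccc(C)cc2)C(c2ccc(F)cc2)OC1`, differs from compound 3 by 4-methylbenzyl in place of 4-methylphenyl on an amide-type nitrogen. For the measured compounds named here, no measured step covers this change; compound 1, which also carries a benzyl group on the amide nitrogen, sits at the limit, so nothing points to compound 4 rising above it. Compound 4 is thus expected to remain at the limit, estimated at 200000 nM in this assay. The estimated range for compound 4 runs from 100000 nM to 1000000 nM. The expected step is a step that the limit leaves unreadable from compound 3 to compound 4, not beyond scatter.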

Compound 4, half-maximal inhibitory concentration: > 100000 nM
Compound 4: no number, only a limit; the forecaster's own chance of this, stated with the estimate: 85%; the middle value lies beyond the limit too.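

Compound 3 and compound 4 both stand at a limit, not a number, so no step between them can be read: the limit of > 100000 nM in this assay, at which 4 of the 4 values shown sit.

The compounds shown leave open which change to the shared core, if any, would bring a value inside the measurable range.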